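A smaller group on the carbonyl carbon of compound 2

The compounds below may be only part of what the source reports. "The series", "measured", "known", "first", "only" and "open" are said of these compounds alone.

In a physicochemical assay for lipophilicity, using the shake flask method, measured as octanol-water partition, at pH 7.4 (a higher number here means a more lipophilic compound, a lower number a more polar compound), compound 1 `CC(=O)N[C@@H]1CCC[C@H](C(=O)Nc2cc(-c3cnn4c3CN(C)CC4)c(Cl)cn2)C1` gives 2.1 and compound 2 `CC(=O)N[C@@H]1CCC[C@H](C(=O)Nc2cc(-c3cnn4c3CC(C)(C)C4)c(Cl)cn2)C1` gives 3.8, the higher of the two numbers. Compound 3 `CC1(C)Cc2c(-c3cc(NC(=O)[C@H]4C[C@@H](O)C4)ncc3Cl)cnn2C1` differs from compound 2 by one change: 3-hydroxycyclobutyl in place of 3-acetamidocyclohexyl on a carbonyl carbon, with 3-hydroxycyclobutyl in place of 3-acetamidocyclohexyl on a carbonyl carbon. Going by the values given here, the only measured step, a number 1.70 log units higher from compound 1 to compound 2 (beyond the scatter), is large, but it lies on an aromatic carbon, so it offers a scale and no direction for this change. In this assay a moderate fall is expected, smaller than that step: a number 0.80 log units lower from compound 2 to compound 3 (beyond the scatter). The estimated value for compound 3 is 3, with a range from 2.5 to 3.5.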

Compound 3, distribution coefficient: 3.2
Estimate against measurement, compound 3: 0.20 log units below; low and high end bracket the measured number.
By their numbers in this assay, from the lowest: compound 1; then compound 3; then compound 2.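

Going by these compounds alone, with 3-acetamidocyclohexyl common to compound 1 and compound 2, the group on the carbonyl carbon varies here for the first time, and in this assay the change gives a number 0.60 log units lower from compound 2 to compound 3 (beyond the scatter). The entering group has fewer heavy atoms, yet its counts of hydrogen-bond donors and acceptors match those of the group it replaces. No measurement here accounts for the size of this step.

From the compounds shown here alone, the ring and its substituent changed together, so their shares in the step remain open. A 3-hydroxycyclohexyl or a cyclobutyl carrying an amine would bear on that question.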